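Methoxy in place of hydroxymethyl: a second pair at the limit

The source may hold more compounds than are shown below. What is called first, only, known or untested is meant among the compounds shown, and "the series" means these compounds.

Compound 1 `Nc1nc(-c2ccc(CO)cc2)nc2sc(-c3ccccc3)nc12` carries a hydroxymethyl on an aromatic carbon of a six-membered aromatic ring of carbon only. In a functional assay on CHO cells for antagonist activity at adenosine receptor A2b (Homo sapiens), read by cAMP accumulation, with a stated time of 10 min (on this read-out lower numbers stand for stronger inhibition and higher numbers for weaker inhibition), compound 1 gives > 30000 nM, which is a limit of the assay and not a number. Compound 2 `COc1ccc(-c2nc(N)c3nc(-c4ccccc4)sc3n2)cc1` differs from it by methoxy in place of hydroxymethyl on an aromatic carbon. In this assay compound 2 also returns only a limit, > 30000 nM. The step that the two limits leave unreadable from compound 1 to compound 2 therefore cannot be sized; both ends sit at the limit of > 30000 nM in this assay, at which 3 of the 3 values shown sit.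

Compound 3 `Nc1nc(-c2cccc(CO)c2)nc2sc(-c3ccco3)nc12` has a different core, and the difference between the two cores is not broken down here. In this assay compound 3 gives > 30000 nM, again a limit of the assay. Compound 4 `COc1cccc(-c2nc(N)c3nc(-c4ccco4)sc3n2)c1`, not yet measured, differs from compound 3 by methoxy in place of hydroxymethyl on an aromatic carbon. This is the same kind of change as from compound 1 to compound 2, though the place is not identical: in the earlier pair the group sits para to a large group, here it sits meta to a large group.

Within the data shown here, all three values shown sit at the limit of > 30000 nM in this assay, at which 3 of the 3 values shown sit, so no measured step reads at all, and compound 4 cannot be anchored to any number. The expectation for the step that the limit leaves unreadable from compound 3 to compound 4 is that it stays unreadable, resting on compound 1 and compound 2 both at the limit of > 30000 nM in this assay, at which 3 of the 3 values shown sit, and on compound 3 at > 30000 nM. Compound 4 is estimated at 50000 nM, most likely reported again as a limit.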

Compound 4, half-maximal inhibitory concentration: > 30000 nM
Compound 4 ended at the assay's limit; the forecaster's own chance of this, stated with the estimate: 85%; the middle value is on the limit's open side.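

In this assay compound 4 gives > 30000 nM, a limit of the assay and not a number. No step can be read from compound 3 to compound 4, because neither compound has a value that is a number: the limit of > 30000 nM in this assay, at which 4 of the 4 values shown sit.

The compounds shown leave open whether methoxy in place of hydroxymethyl on an aromatic carbon changes inhibition at all, and how far each compound lies past the limit.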